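The source may report more compounds than this note shows. Statements on the series, on what has been measured and on what is new or still open speak of the compounds shown alone.

Measured compounds:
compound 1 `O=C(Nc1cccc(-n2cc(-c3ccncc3)c(-c3ccc(Cl)c(O)c3)n2)c1)Nc1ccc(Cl)c(Cl)c1` — 3570 nM
compound 2 `COc1cc(-c2nn(-c3cccc(NC(=O)c4ccc(Cl)c(C(F)(F)F)c4)c3)cc2-c2ccncc2)ccc1Cl` — limit, > 32500 nM
compound 3 `COc1cc(-c2nn(-c3cccc(NC(=O)c4ccccc4)c3)cc2-c2ccncc2)ccc1Cl` — limit, > 100000 nM

Within the data shown here, in a functional assay on LOX IMVI cells (Homo sapiens) for inhibition, read by sulforhodamine B assay, with a stated time of 48 h (on this read-out higher numbers stand for weaker inhibition of growth and lower numbers for stronger inhibition of growth), compound 1 gives 3570 nM, the only number among the three values shown. Compound 2 reaches only a limit, > 32500 nM. Compound 3 likewise reaches only a limit, > 100000 nM. The step that the two limits leave unreadable from compound 2 to compound 3 therefore cannot be sized.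

Compound 4 `O=C(Nc1cccc(-n2cc(-c3ccncc3)c(-c3ccc(Cl)c(O)c3)n2)c1)Nc1ccc(Cl)c(C(F)(F)F)c1` differs from compound 1 by trifluoromethyl in place of chloro on an aromatic carbon. Among the measured compounds shown here, no measured step covers this exchange; compound 2 carries a trifluoromethyl but differs from compound 1 at other places as well, so it gives no reading for the change. With nothing to point to, the expectation for compound 4 is a step of a 1.0-fold lower number from compound 1 to compound 4 (0.01 log units; within the scatter), not beyond the scatter. Compound 4 is estimated at 3500 nM, between 1200 nM and 12000 nM, pending the measurement.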

Compound 4, concentration for total growth inhibition: 1150 nM
Compound 4: middle estimate off by 3.0-fold (0.48 log units), on the high side; measured number below the stated range.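

In this assay the exchange on this aromatic carbon, ortho to a chloro group, reads as a 3.1-fold lower number from compound 1 to compound 4 (0.49 log units; beyond the scatter) and shows that the place accepts a group larger than chloro with stronger inhibition of growth. Among these compounds, this is the only readable step so far, the earlier one being left unreadable by two limits. Nothing at hand speaks to a cause for this step. Open, as far as these compounds go, is how a methyl group, a bromo group or a nitrile would read on this same carbon. Also open, from the compounds shown here alone, is whether the exchange gives a similar step with the methoxy group of compound 2 in place of the hydroxyl of compound 1.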